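Shortening the amide side chain on the shared core

The source may hold more compounds than are shown below. What is called first, only, known or untested is meant among the compounds shown, and "the series" means these compounds.

Compound 1 `CN(C)C(=O)/C=C/c1ccc2noc(-c3ccccc3)c2c1` and compound 2 `CNC(=O)/C=C/c1ccc2noc(-c3ccccc3)c2c1` share one core and differ only at the amide nitrogen. In an assay for inhibition of inositol hexakisphosphate kinase 2 (Homo sapiens), read by colorimetric assay, coupled enzyme assay and malachite green, with a stated time of 120 min, in the presence of a further agent that is not named here (on this read-out lower numbers stand for stronger inhibition and higher numbers for weaker inhibition), compound 1 gives 40300 nM, and compound 2 gives 58200 nM. Among the compounds with values here, the only measured step, a 1.4-fold higher number from compound 1 to compound 2 (0.16 log units; within the scatter), does not separate the two. Of the two numbers compound 2's is the higher, but its gap to compound 1 lies within the scatter, so neither is distinguished from the other.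

Compound 3 `CNC(=O)c1ccc2noc(-c3ccccc3)c2c1` is not yet measured. It differs from compound 2 by methylcarbamoyl in place of 2-(methylcarbamoyl)ethenyl on an aromatic carbon. Within the data shown here, no measured step bears on this change: the single step between compound 1 and compound 2 concerns the amide nitrogen, not the linker. For compound 3 the step in this assay is therefore expected to be small, a 1.1-fold higher number from compound 2 to compound 3 (0.05 log units; within the scatter), with no direction that can be trusted. Compound 3 is expected to give 65000 nM in this assay, with a range from 20000 nM to 220000 nM.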

Compound 3, half-maximal inhibitory concentration: 2120 nM
The estimate for compound 3 lay 31-fold (1.49 log units) above the measured number, and the stated range ends above it.
By their numbers in this assay, from the lowest: compound 3; then compounds 1 and 2 (each within the scatter of the next).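

Unlike the earlier step at the amide nitrogen, the change on the aromatic carbon moves the number well beyond the scatter: in this assay, methylcarbamoyl in place of 2-(methylcarbamoyl)ethenyl gives a 27-fold lower number from compound 2 to compound 3 (1.44 log units; beyond the scatter) on this read-out. Measured against the dimethyl amide, the shorter group gives a 19-fold lower number from compound 1 to compound 3 (1.28 log units; beyond the scatter) as well, so the drop appears from both ethenyl amides shown and this place on the shared core is the one that responds. Nothing measured here explains why the shorter group gives the lower number.

From the compounds shown here alone, it remains open whether the amide nitrogen matters more once the group is short, as a dimethylcarbamoyl group at this place would test. Also open, going by these compounds, is how a carboxylic acid, an unsubstituted carboxamide or an amine would compare with methylcarbamoyl on this aromatic carbon.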